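A few compounds are considered here, and "the series" means these few. Any claim that something is new, unique, unknown or untested is made for them only; others in the source may bear on it.

Compound 2, `CC(=O)Oc1ccccc1C(=O)O[C@H]1CO[C@H]2[C@@H]1OC[C@H]2OC(=O)c1ccccc1CO[N+](=O)[O-]`, was measured in an ADME assay on a cell-free system (plasma, Homo sapiens) for metabolic stability, with Plasma (Rattus norvegicus) as the target, read by HPLC, at pH 7.4 (a higher number here means that the compound lasts longer, a lower number that the compound disappears faster), where compound 2 gives 0.045 h. Among the measured compounds shown here, only two numbers exist so far, and compound 2 gives the smaller of them; its sole neighbour, compound 1, `CC(=O)Oc1ccccc1C(=O)O[C@H]1CO[C@H]2[C@@H]1OC[C@H]2OC(=O)c1snnc1C`, gives 0.0642 h in this assay, yet the step of a 1.4-fold lower number from compound 1 to compound 2 (0.15 log units; within the scatter) stays within the scatter, so the two cannot be told apart on these data. Compound 3, `CC(=O)Oc1ccccc1C(=O)O[C@H]1CO[C@H]2[C@@H]1OC[C@H]2OC(=O)c1cccc(CO[N+](=O)[O-])c1`, keeps every atom of compound 2 and differs only in how they are joined: 3-((nitrooxy)methyl)phenyl in place of 2-((nitrooxy)methyl)phenyl on a carbonyl carbon. For the measured compounds named here, no measured step bears directly on this rearrangement. Going by the values given here, the single step recorded, a 1.4-fold lower number from compound 1 to compound 2 (0.15 log units; within the scatter), exchanged the whole ring on the carbonyl carbon for a different one and still remained within the scatter, which gives no hint that a smaller rearrangement within the same ring would move the number far. The expectation is therefore for no step beyond the scatter, a 1.1-fold higher number from compound 2 to compound 3 (0.05 log units; within the scatter). On that basis compound 3 is estimated to give 0.05 h in this assay, with the expected range running from 0.02 h to 0.12 h.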

Compound 3, half-life: 0.0433 h
The estimate for compound 3 lay 1.2-fold (0.06 log units) above the measured number; the range from low to high includes it.
By their numbers in this assay, from the lowest: compounds 3, 2 and 1 (each within the scatter of the next).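

Placing 3-((nitrooxy)methyl)phenyl in place of 2-((nitrooxy)methyl)phenyl on the carbonyl carbon gives, in this assay, (a 1.0-fold lower number from compound 2 to compound 3 (0.02 log units; within the scatter)), which shows that for this pair of isomers the two attachments of the same group on the ring cannot be told apart on these data. Set against the 4-methyl-1,2,3-thiadiazol-5-yl group, the new group gives a similar reading (a 1.5-fold lower number from compound 1 to compound 3 (0.17 log units; within the scatter)), so that all three groups tried on this carbonyl carbon now stand within the scatter of one another, where earlier only two could be compared. Nothing available offers an explanation for this sameness.

What the compounds shown leave open is whether a group of another kind on this carbonyl carbon, such as a simple alkyl chain or a phenyl ring carrying an amine or a carboxylic acid, would give a number beyond the scatter. They also leave open how far the half-life answers to a change in the other ester of the shared core, which stays the same in all three compounds.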